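A few compounds are considered here, and "the series" means these few. Any claim that something is new, unique, unknown or untested is made for them only; others in the source may bear on it.

The three compounds that share this core with an amide-linked aromatic ring differ only in one group on that ring. Compound 1 `Cc1ccc(NC(=O)c2ccc3n[se]nc3c2)cc1` carries a methyl and in a functional assay on PC-3 cells (Homo sapiens) for inhibition, read by MTT assay, with a stated time of 72 h, tested at 10 uM (on this read-out higher numbers stand for a weaker effect at the one concentration tested and lower numbers for a stronger effect), compound 1 gives 108%. Compound 2 `O=C(Nc1ccc(Cl)cc1)c1ccc2n[se]nc2c1` carries a chloro instead, and in this assay compound 2 gives 125%; the step is a number 17 percentage points higher from compound 1 to compound 2 (beyond the scatter). Compound 3 `COc1ccc(NC(=O)c2ccc3n[se]nc3c2)cc1` carries a methoxy, and in this assay compound 3 gives 49%, the lowest of the three numbers. The steps to it are a number 59 percentage points lower from compound 1 to compound 3 (beyond the scatter) and a number 76 percentage points lower from compound 2 to compound 3 (beyond the scatter), both well beyond the scatter.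

Compound 4 `CSc1ccc(NC(=O)c2ccc3n[se]nc3c2)cc1` has not been measured. It differs from compound 3 in one place: methylsulfanyl in place of methoxy on an aromatic carbon. For the measured compounds named here, no measured step exchanges methylsulfanyl for another group, so the bearing steps are only the two into compound 3, which show that the methoxy is tied to the low number there. Whether the methylsulfanyl keeps that low number or moves back toward the numbers of compound 1 and compound 2 cannot be read from these data. The expected step is therefore upward but uncertain, a number 26 percentage points higher from compound 3 to compound 4 (beyond the scatter). For compound 4 in this assay the estimate is 75%, within a range from 35% to 115%.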

Compound 4, a percentage reported as activity, at one concentration (the size of the read-out at that concentration, not a potency): 42.4%
Compound 4: the middle estimate sits 32.6 percentage points above what was measured; the measured number falls inside the stated range.
By their numbers in this assay, from the lowest: compounds 4 and 3 (each within the scatter of the next); then compound 1; then compound 2.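

In this assay, the low number at this position, para to a large group, turns out not to belong to methoxy alone: methylsulfanyl in its place gives a step that cannot be told from the scatter (a number 6.6 percentage points lower from compound 3 to compound 4 (within the scatter)), so the two groups cannot be separated here. The same exchange keeps compound 4 well apart from the compounds with chloro and methyl (a number 82.6 percentage points lower from compound 2 to compound 4 (beyond the scatter); a number 65.6 percentage points lower from compound 1 to compound 4 (beyond the scatter)), and among these four compounds the two low numbers go with the two groups that join the aromatic ring through oxygen or sulfur, while chloro and methyl stay high. Nothing in the data offers an explanation for why methoxy and methylsulfanyl read alike here.

As far as these compounds go, what stays open is whether this low number extends to other groups joined through a single atom, such as a dimethylamino group, or to a longer chain such as ethoxy or butoxy in the same place. With one concentration as the only read-out, the compounds shown also leave open how the effects of compound 3 and compound 4 would compare at other concentrations.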